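Swapping an Amidine Amino Group for Quinolin-3-yl

The source may hold more compounds than are shown below. What is called first, only, known or untested is meant among the compounds shown, and "the series" means these compounds.

These compounds share a core of three linked methylpyrrole amides ending in a dimethylaminopropyl amide, and they differ at the group attached to the amidine carbon at the far end. Compound 1, `CC(C)CCc1sc(NC(=O)c2cc(NC(=O)c3cc(NC(=N)c4cccc(F)c4)cn3C)cn2C)nc1C(=O)NCCCN(C)C`, carries a fluorophenyl on that carbon and an extra thiazole unit; in an ADME assay on HEK293 cells (Homo sapiens) for cytotoxicity, read by fluorescence and resazurin assay, with a stated time of 20 h (a higher number here means that more compound is tolerated, a lower number that less compound is tolerated), compound 1 gives 18 ug/mL. Compound 2, `CN(C)CCCNC(=O)c1cc(NC(=O)c2cc(NC(=O)c3cc(NC(=N)N)cn3C)cn2C)cn1C`, carries a plain amino group there, and in this assay compound 2 stands at "not determined" (no result reported), so no number is available for it.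

Compound 3, `CN(C)CCCNC(=O)c1cc(NC(=O)c2cc(NC(=O)c3cc(NC(=N)c4cnc5ccccc5c4)cn3C)cn2C)cn1C`, is compound 2 with one change: quinolin-3-yl in place of amino on a carbon with a double bond to nitrogen. For the measured compounds named here, no pair of measured compounds shows the effect of this change, so no step size can be computed, and the expectation for compound 3 in this assay rests only on compound 1, which gives 18 ug/mL, the one number that exists. On that basis compound 3 is expected to lie in the same broad region, estimated at 30 ug/mL, with a plausible range from 10 ug/mL to 90 ug/mL.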

Compound 3, half-maximal cytotoxic concentration: > 32 ug/mL
Compound 3: only a limit was reported; the forecaster's own chance of this, stated with the estimate: 30%; middle value at least 1.0-fold (0.02 log units) away from the limit.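

No step can be read between compound 2 and compound 3 in this assay, as compound 2 has no reported number. Compound 3 gives > 32 ug/mL, which is a limit of the assay and not a number. From the compounds shown here alone, whether quinolin-3-yl in place of amino changes the tolerated concentration, in either direction and by how much, remains open.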